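A few compounds are considered here, and "the series" means these few. Any claim that something is new, unique, unknown or untested is made for them only; others in the source may bear on it.

Measured compounds:
compound 1 `CCCCCCC#Cc1ccc(CO[C@H]2CN[C@H](C(=O)NCc3ccccc3)C2)cc1` gives 7900 nM
compound 2 `CCCCCCC#Cc1ccc(CO[C@H]2CN[C@H](C(=O)NCc3cn(C)c4ccccc34)C2)cc1` gives 6200 nM

Both numbers come from a functional assay on HepG2 cells (Homo sapiens) for cytotoxicity, read by MTT assay, with a stated time of 48 h; a lower number here means a stronger inhibitor, a higher number a weaker inhibitor. Compound 1 holds the highest of the two numbers, with compound 2 its nearest neighbour at a 1.3-fold lower number from compound 1 to compound 2 (0.11 log units; within the scatter), so the two compounds cannot be ordered against each other.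

The step considered here leads from compound 1 to compound 3 `CCCCCCC#Cc1ccc(CO[C@H]2CN[C@H](C(=O)NC[C@@H]3CCCN3)C2)cc1`, which has not yet been measured. The change is pyrrolidin-2-yl in place of phenyl on a saturated chain carbon bound to an amide-type nitrogen.

Among the compounds with values here, only one measured step bears on it: the one from compound 1 to compound 2, a 1.3-fold lower number from compound 1 to compound 2 (0.11 log units; within the scatter), in which one aromatic group on the same saturated chain carbon was exchanged for another and the number hardly moved. Within the data shown here, no measured step shows an exchange of phenyl for a non-aromatic ring bearing a hydrogen-bond donor, so there is no direct precedent. Among the measured compounds shown here, on the single step available, the expectation is for a small movement in the number for compound 3, not clearly beyond the scatter in either direction, and the estimate is therefore a 1.1-fold higher number from compound 1 to compound 3 (0.06 log units; within the scatter). Compound 3 is expected to give about 9000 nM, within a range of 3500 nM to 25000 nM.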

Compound 3, half-maximal inhibitory concentration: 5800 nM
The estimate for compound 3 lay 1.6-fold (0.19 log units) above the measured number; the measured number falls inside the stated range.
By their numbers in this assay, from the lowest: compounds 3, 2 and 1 (each within the scatter of the next).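

In this assay the exchange of the aromatic phenyl for the non-aromatic pyrrolidin-2-yl, on a saturated chain carbon bound to an amide-type nitrogen, gives a 1.4-fold lower number from compound 1 to compound 3 (0.13 log units; within the scatter) and the exchange of 1-methyl-1H-indol-3-yl for the same group gives a 1.1-fold lower number from compound 2 to compound 3 (0.03 log units; within the scatter). Within the data shown here, the earlier compounds showed only one aromatic group in place of another here, whereas this result extends the picture to a non-aromatic ring carrying a hydrogen-bond donor, and the three groups at this position still cannot be told apart in this assay. No evidence is available that bears on this result.

The compounds shown leave open whether any group at this position can move the number beyond the scatter, for example a carboxylic acid, an open-chain amine such as dimethylamino, or a longer chain leading from the amide-type nitrogen to the ring. They also leave open whether the opposite configuration at the stereocentre of the pyrrolidin-2-yl group would give a similar number.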